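This account rests on a few compounds, and the source may have more. Where it says the series, first, only, none or still open, it means among the compounds named here.

Series notes on cytotoxicity. In an ADME assay on BaF3 cells (Mus musculus) for cytotoxicity (on this read-out lower numbers stand for an effect already at smaller amounts and higher numbers for an effect only at larger amounts of compound), compound 1 `Cc1nc(C)c(Cn2ncc3c(Nc4ccc(OC(F)(F)F)cc4)ncnc32)s1` gives > 10000 nM, which is a limit of the assay and not a number. Compound 2 `O=C(c1cc2c(Nc3ccc(OC(F)(F)F)cc3)ncnc2s1)N1CCC(O)CC1` likewise reaches only a limit in this assay, > 10000 nM. Compound 3 `CNC(=O)c1cccc(-c2cc(Nc3ccc(OC(F)(F)F)cc3)ncn2)c1` also sits at a limit, > 10000 nM. Compound 1 therefore stands where the whole set stands: the limit of > 10000 nM in this assay, at which 3 of the 3 values shown sit. Compound 4 `FC(F)(F)Oc1ccc(Nc2ncnc3c2cnn3Cc2ccccc2)cc1` differs from compound 1 by phenyl in place of 2,4-dimethyl-1,3-thiazol-5-yl on a saturated chain carbon bound to an aromatic nitrogen. Among the compounds with values here, no step between measured compounds is known, so no size of effect can be read from them. The expected step that the limit leaves unreadable from compound 1 to compound 4 is none beyond the scatter, because every value shown sits at the limit (the limit of > 10000 nM in this assay, at which 3 of the 3 values shown sit). Compound 4 is expected to give 15000 nM in this assay, within 5000 nM to 50000 nM, most likely again as a limit.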

Compound 4, half-maximal effective concentration: > 10000 nM
Compound 4: no number, only a limit; the forecaster's own chance of this, stated with the estimate: 85%; the middle value lies beyond the limit too.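

Within the data shown here, no step from compound 1 to compound 4 can be read in this assay, because both values are limits: the limit of > 10000 nM in this assay, at which 4 of the 4 values shown sit. The compounds shown leave open which change to the shared core, if any, would give a readable number.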